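Aryl swap on the pyrazole nitrogen, compound 1 to compound 3

A few compounds are considered here, and "the series" means these few. Any claim that something is new, unique, unknown or untested is made for them only; others in the source may bear on it.

Compound 1 `Cc1c(C(=O)Nc2ccc(C(F)(F)F)cc2)cnn1-c1ccc(F)c(Cl)c1` gives 1300 nM in a functional assay with Homo sapiens as the target; a higher number here means a weaker inhibitor, a lower number a stronger inhibitor. Compound 2 `Cc1ccccc1NC(=O)c1cnn(-c2ccc(F)cc2)c1C` gives 1100 nM in this assay, within the scatter of compound 1. Compound 3 `Cc1c(C(=O)Nc2ccc(C(F)(F)F)cc2)cnn1-c1cccc(Cl)c1Cl` has not been measured; it differs from compound 1 by 2,3-dichlorophenyl in place of 3-chloro-4-fluorophenyl on an aromatic nitrogen. Going by the values given here, no step between measured compounds with this change is known, so the expectation rests on the single anchor. The step of no change at the digits printed from compound 1 to compound 3 (within the scatter) is expected to be no larger than the scatter. Compound 3 is therefore estimated at 1300 nM in this assay, with a range of 500 nM to 3500 nM.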

Compound 3, half-maximal inhibitory concentration: 1600 nM
Beside the measured number, compound 3's estimate is 1.2-fold (0.09 log units) below it; the range from low to high includes it.
By their numbers in this assay, from the lowest: compounds 2, 1 and 3 (each within the scatter of the next).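

In this assay, going by these compounds alone, 2,3-dichlorophenyl in place of 3-chloro-4-fluorophenyl on the aromatic nitrogen gives a 1.2-fold higher number from compound 1 to compound 3 (0.09 log units; within the scatter), the first step that can be read at this position. With the rest of compound 1 held constant, these two halogenated phenyl groups cannot be told apart in this read-out. No available evidence bears on the reason for this result.

As far as these compounds go, whether a phenyl ring carrying an amine or a carboxylic acid would move the number beyond the scatter remains open. A benzyl group on this nitrogen poses the same question.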